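Adding chloro to a sulfamoylamino benzamide: what to expect

The source may report more compounds than this note shows. Statements on the series, on what has been measured and on what is new or still open speak of the compounds shown alone.

Compound 3 `CCN1CCCC1CNC(=O)c1cc(NS(=O)(=O)NC)ccc1OC` carries a (methylsulfamoyl)amino group on the shared core, and in a functional assay on the whole organism for inhibition, with Canis familiaris (Canis lupus familiaris) as the target (on this read-out higher numbers stand for an effect only at larger amounts of compound and lower numbers for an effect already at smaller amounts), compound 3 gives > 1 mg/kg, which is a limit of the assay rather than a number (the limit of > 1 mg/kg in this assay, at which 1 of the 3 values shown sits). Its relatives compound 1 `CCN1CCCC1CNC(=O)c1cc(N(C)S(C)(=O)=O)c(Cl)cc1OC` and compound 2 `CCN1CCCC1CNC(=O)c1cc(N(C)S(=O)(=O)N(C)C)c(Cl)cc1OC` both carry chloro; in this assay compound 1 gives 0.1 mg/kg and compound 2 gives 0.1 mg/kg, and the step of no change at the digits printed from compound 1 to compound 2 (within the scatter) concerns only the sulfonyl end, not the ring. Compound 4 `CCN1CCCC1CNC(=O)c1cc(NS(=O)(=O)NC)c(Cl)cc1OC` is compound 3 with chloro in place of hydrogen on an aromatic carbon. Among the measured compounds shown here, no measured step isolates this change, since compounds 1 and 2 differ from compound 3 in more than the chloro. The expected step is an at least 2.5-fold lower number from compound 3 to compound 4 (0.39 log units; beyond the scatter), toward smaller doses. Compound 4 is estimated at 0.4 mg/kg, with a range from 0.1 mg/kg to 2 mg/kg.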

Compound 4, dose for half-maximal effect: > 1 mg/kg
Compound 4: no number, only a limit; the forecaster's own chance of this, stated with the estimate: 30%; middle value at least 2.5-fold (0.39 log units) away from the limit.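

In this assay, chloro on the aromatic carbon does not by itself bring this series to the doses of compounds 1 and 2. With chloro held in place, the change of the group ortho to it gives an at least 10-fold higher number from compound 2 to compound 4 (1.00 log units; beyond the scatter), and likewise an at least 10-fold higher number from compound 1 to compound 4 (1.00 log units; beyond the scatter). Compound 4 gives > 1 mg/kg, which is a limit and not a number, so the step for chloro in place of hydrogen cannot be read: the limit of > 1 mg/kg in this assay, at which 2 of the 4 values shown sit.

On these data alone, what remains open is the effect of chloro itself, and whether a methyl on the nitrogen attached to the aromatic carbon, as in a (methylsulfamoyl)(methyl)amino group, accounts for the gap.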